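The source may report more compounds than this note shows. Statements on the series, on what has been measured and on what is new or still open speak of the compounds shown alone.

Notes on the series. Compound 1 `Cc1ccc2[nH]c(C(=O)N[C@H]3CN(S(=O)(=O)c4ccccc4)C[C@@H]3C(=O)NC[C@H]3CCCN3)cc2c1`, compound 2 `Cc1ccc2[nH]c(C(=O)N[C@H]3CN(S(=O)(=O)c4ccccc4)C[C@@H]3C(=O)NC[C@@H]3CCCN3C)cc2c1` and compound 3 `Cc1ccc2[nH]c(C(=O)N[C@H]3CN(S(=O)(=O)c4ccccc4)C[C@@H]3C(=O)N[C@@H]3CCCNC3)cc2c1` share one core and differ only in the group carried on the amide-type nitrogen. In a functional assay on HEK293 cells for agonist activity at growth hormone secretagogue receptor type 1 (Homo sapiens), read by HTRF and inositol phosphate accumulation, with a stated time of 90 min, in the presence of a further agent that is not named here (a higher number here means a larger maximal response, a lower number a smaller maximal response), compound 1 gives 94%, compound 2 gives 87% and compound 3 gives 91%. Compound 3 stands second highest of the three numbers, nearest to compound 1 and furthest from compound 2, but all three lie within the scatter of one another: a number 3 percentage points lower from compound 1 to compound 3 (within the scatter), a number 4 percentage points higher from compound 2 to compound 3 (within the scatter), and a number 7 percentage points lower from compound 1 to compound 2 (within the scatter). None of these exchanges of the group on the amide-type nitrogen moves the maximal response beyond the scatter.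

Compound 4 `Cc1ccc2[nH]c(C(=O)N[C@H]3CN(S(=O)(=O)c4ccccc4)C[C@@H]3C(=O)N[C@H]3CCCNC3)cc2c1` is the next member. (the two compounds have the same atoms and bonds and differ only in configuration as drawn: 1 of 3 stereo elements differ; a stereocentre at a saturated ring carbon is drawn R in compound 3 and S in compound 4). Among the compounds with values here, no measured step in this set concerns a change of configuration alone; the steps that touch the same position, a number 3 percentage points lower from compound 1 to compound 3 (within the scatter) and a number 4 percentage points higher from compound 2 to compound 3 (within the scatter), exchanged the whole group and still stayed within the scatter. On that basis the step of a number 3 percentage points lower from compound 3 to compound 4 (within the scatter) is expected to remain within the scatter as well, with no set direction. For compound 4 a maximal response of 88% is estimated, with a range from 72% to 100%.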

Compound 4, largest response reached (Emax), in percent of the reference or control that the assay uses: 98%
For compound 4 the middle estimate is 10 percentage points below the measured one, within the range that was stated.
By their numbers in this assay, from the lowest: compounds 2, 3, 1 and 4 (each within the scatter of the next, the first and the last beyond it).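

Within the data shown here, compound 3 and compound 4 give the first reading of a change of configuration alone: at the saturated ring carbon of the piperidin-3-yl group, inversion gives a number 7 percentage points higher from compound 3 to compound 4 (within the scatter) in this assay, so at this position neither drawn configuration stands apart from the other. Among these compounds, the S-drawn group also gives the first exchange on the amide-type nitrogen to pass the scatter, a number 11 percentage points higher from compound 2 to compound 4 (beyond the scatter), where the R-drawn group gave only a number 4 percentage points higher from compound 2 to compound 3 (within the scatter), though the S-drawn group stays level with (pyrrolidin-2-yl)methyl, at a number 4 percentage points higher from compound 1 to compound 4 (within the scatter). The split between these two readings from compound 2 is small and rests on a single structural distinction: the fact that compounds 3 and 4 differ only in the configuration as drawn.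

The compounds shown leave open whether configuration at this ring carbon matters any more for a 1-methylpiperidin-3-yl group, a piperidin-4-yl group or an open-chain primary amine on the amide-type nitrogen. As far as these compounds go, how the maximal response follows the other stereo elements of the shared core, or a carboxylic acid in place of the ring amine, also remains open.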